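Moving One Methoxy Group: What Is Expected in Cells

This account rests on a few compounds, and the source may have more. Where it says the series, first, only, none or still open, it means among the compounds named here.

Compound 1, `COc1cc(OC)c(-c2nc3cc(/C=C4\SC(=O)NC4=O)ccc3[nH]2)cc1OC`: in a functional assay on PC-3 cells (Homo sapiens) for inhibition, read by MTT assay, with a stated time of 48 h (on this read-out lower numbers stand for stronger inhibition and higher numbers for weaker inhibition), compound 1 gives 6320 nM.
Compound 2, `COc1cc(OC)c(-c2nc3cc(/C=C4\SC(=O)N(CC(=O)N5CCOCC5)C4=O)ccc3[nH]2)cc1OC`: compound 2 gives 11700 nM.
Compound 3, `COc1cc(-c2nc3cc(/C=C4\SC(=O)N(Cc5cccc(C)c5)C4=O)ccc3[nH]2)cc(OC)c1OC`: compound 3 gives 4370 nM.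

Compound 3 has the lowest number of the three, but only compound 2 lies beyond the scatter from it; compound 1 sits within the scatter. Among the measured compounds shown here, the single step between neighbours, a 1.9-fold higher number from compound 1 to compound 2 (0.27 log units; within the scatter), concerns the amide-type nitrogen and not the aryl group. Compound 4, `COc1cc(OC)c(-c2nc3cc(/C=C4\SC(=O)N(Cc5cccc(C)c5)C4=O)ccc3[nH]2)cc1OC`, differs from compound 3 by 2,4,5-trimethoxyphenyl in place of 3,4,5-trimethoxyphenyl on an aromatic carbon. For the measured compounds named here, no measured pair isolates this change: compounds 1 and 2 carry the entering group and compound 3 the leaving one, with other differences alongside. The account therefore expects no step beyond the scatter in this assay, a 1.1-fold higher number from compound 3 to compound 4 (0.06 log units; within the scatter). For compound 4 the estimate is 5000 nM, between 2000 nM and 13000 nM.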

Compound 4, half-maximal inhibitory concentration: 630 nM
Compound 4: middle estimate off by 7.9-fold (0.90 log units), on the high side; measured number outside the range, below it.
By their numbers in this assay, from the lowest: compound 4; then compounds 3, 1 and 2 (each within the scatter of the next, the first and the last beyond it).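

In this assay, rearranging the methoxy groups on an aromatic carbon between two ring nitrogen atoms proves to matter, with a 6.9-fold lower number from compound 3 to compound 4 (0.84 log units; beyond the scatter) although the leaving and entering groups have the same atoms and counts. The amide-type nitrogen also now matters: 3-methylbenzyl in place of hydrogen gives a 10-fold lower number from compound 1 to compound 4 (1.00 log units; beyond the scatter), and 3-methylphenyl in place of (morpholin-4-yl)carbonyl on the saturated chain carbon gives a 19-fold lower number from compound 2 to compound 4 (1.27 log units; beyond the scatter), whereas the earlier step there stayed within the scatter.

Nothing available bears on why the rearrangement has this effect. The compounds shown leave open how a longer chain ending in 3-methylphenyl on that nitrogen, or an amine in place of one methoxy group, would read.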